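This account rests on a few compounds, and the source may have more. Where it says the series, first, only, none or still open, it means among the compounds named here.

Of the compounds shown here, two have been tested in an assay on isolated protein for inhibition of Indoleamine 2,3-dioxygenase 1 (Homo sapiens), with a stated time of 60 min, tested at 1 uM; a lower number here means less inhibition, a higher number more inhibition at the concentration tested (going by the name of the read-out). Compound 1 `N#Cc1ccc(NC(=O)NCc2cnc3scc(-c4ccc(Br)cc4)n23)cc1` gives 97% there. Compound 2 `CN(CC(=O)NCc1cnc2scc(-c3ccc(Br)cc3)n12)C(=O)c1ccccc1` gives 50%, the lower of the two numbers, and the gap to compound 1 lies beyond the scatter. Compound 3 `CN(CC(=O)NCc1cnc2scc(-c3ccc(Br)cc3)n12)C(=O)c1ccc([N+](=O)[O-])cc1` has not yet been measured; it differs from compound 2 in one place: nitro in place of hydrogen on an aromatic carbon. Within the data shown here, no pair of measured compounds shows a change of this kind, so nothing here tells how large a step to expect. The estimated step of no change at the digits printed from compound 2 to compound 3 (within the scatter) is small, within the scatter. Compound 3 is expected to reach 50%, somewhere between 25% and 72%.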

Compound 3, a percentage reported as inhibition, at one concentration (the size of the read-out at that concentration, not a potency): 45%
Compound 3: middle estimate off by 5 percentage points, on the high side, within the range that was stated.
By their numbers in this assay, from the lowest: compounds 3 and 2 (each within the scatter of the next); then compound 1.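

In this assay, nitro in place of hydrogen on the benzoyl ring, para to a large group, gives a number 5 percentage points lower from compound 2 to compound 3 (within the scatter) and so no readable change. Among these compounds, this position therefore accepts a group of 3 heavy atoms with no shift beyond the scatter, something the earlier compounds could not show. Nothing measured here offers an explanation for this result. From the compounds shown here alone, whether an amine or a carboxylic acid at this position would also leave the read-out unchanged remains open. So does the outcome of placing nitro elsewhere on this ring.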